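A Methyl on the Ring Nitrogen, Tested Again

The compounds below may be only part of what the source reports. "The series", "measured", "known", "first", "only" and "open" are said of these compounds alone.

Compound 1, `CCCCCCC(CCO)n1cnc2c(NC)ncnc21`, gives in a functional assay on SW480 cells (Homo sapiens) for antiproliferative activity, read by MTT assay, with a stated time of 48 h (on this read-out higher numbers stand for weaker inhibition and lower numbers for stronger inhibition), the value > 50000 nM, which is a limit of the assay.
Compound 2, `CCCCCCC(CCO)n1cnc2c(N(C)C)ncnc21`, gives in this assay the value > 50000 nM, also a limit.
Compound 3, `CCCCCCCCCC(CCO)n1cnc2c(NC)ncnc21`, gives in this assay the value 4450 nM.

Compound 3 differs from compound 1 by propyl in place of hydrogen on a saturated chain carbon, seven bonds along the chain from an aromatic nitrogen, and this gave an at least 11-fold lower number from compound 1 to compound 3 (1.05 log units; beyond the scatter). Compound 4, `CCCCCCCCCC(CCO)n1cnc2c(N(C)C)ncnc21`, is not yet measured. It differs from compound 3 by methyl in place of hydrogen on a nitrogen on an aromatic ring. The same change has been made once before, from compound 1 to compound 2, as methyl in place of hydrogen on a nitrogen on an aromatic ring, and there it gave a step that the two limits leave unreadable from compound 1 to compound 2; both values sit at the limit of > 50000 nM in this assay, at which 2 of the 3 values shown sit, so the earlier step says nothing about its size or direction. The expectation for compound 4 therefore rests only on the value of compound 3 and on the fact that the earlier pair gave no readable step. Compound 4 is expected to show a 2.0-fold higher number from compound 3 to compound 4 (0.31 log units; beyond the scatter), with an estimated value of 9000 nM and a range from 3000 nM to 50000 nM.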

Compound 4, half-maximal inhibitory concentration: 12200 nM
Beside the measured number, compound 4's estimate is 1.4-fold (0.13 log units) below it, and the stated range covers the measured number.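

In this assay, methylamino to dimethylamino has a readable size on the core of compound 3, where the change gives a 2.7-fold higher number from compound 3 to compound 4 (0.44 log units; beyond the scatter) and no more than that one reading. On the core of compound 1 the same change cannot be read, so this series does not show whether its size or even its direction carries from one core to the other, and the two values there are limits of the assay: the limit of > 50000 nM in this assay, at which 2 of the 4 values shown sit. The propyl change, read the other way round, also gives an at least 4.0-fold lower number from compound 2 to compound 4 (0.61 log units; beyond the scatter) on the dimethylamino core, so its direction holds on both cores, while its size cannot be compared: the same change on two cores in this assay, an at least 11-fold lower number (1.05 log units; beyond the scatter) from compound 1 to compound 3 and an at least 4.0-fold lower number (0.61 log units; beyond the scatter) from compound 2 to compound 4; the limit leaves it open whether they differ.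

The compounds shown leave open whether a free amino group, or ethyl in place of methyl on that nitrogen, would follow the step seen on the core of compound 3. They also leave open whether a still longer chain would give values from which the methyl change could be read on more than one core.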